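Series notes: aryl versus phenylethenyl on the saturated ring carbon

This account rests on a few compounds, and the source may have more. Where it says the series, first, only, none or still open, it means among the compounds named here.

In a functional assay on LOX IMVI cells (Homo sapiens) for antiproliferative activity, with a stated time of 48 h (a higher number here means that more compound is tolerated, a lower number that less compound is tolerated), compound 1 `Cc1cc(O)c(C2=NN(c3ccc(S(N)(=O)=O)cc3)C(c3ccccc3O)C2)cc1Cl` gives 5870 nM and compound 2 `Cc1cc(O)c(C2=NN(c3ccc(S(N)(=O)=O)cc3)C(c3ccccc3Cl)C2)cc1Cl` gives 5800 nM; the step is a 1.0-fold lower number from compound 1 to compound 2 (0.01 log units; within the scatter). Compound 3 `Cc1cc(O)c(C2=NN(c3ccc(S(N)(=O)=O)cc3)C(/C=C/c3ccccc3)C2)cc1Cl` gives 40300 nM, the highest of the three numbers: a 6.9-fold higher number from compound 1 to compound 3 (0.84 log units; beyond the scatter), and equally a 6.9-fold higher number from compound 2 to compound 3 (0.84 log units; beyond the scatter). Compound 4 `COc1ccc(C2CC(c3cc(Cl)c(C)cc3O)=NN2c2ccc(S(N)(=O)=O)cc2)cc1OC` is not yet measured. The change is 3,4-dimethoxyphenyl in place of 2-phenylethenyl on a saturated ring carbon. Both measured steps reaching compound 3 replaced an aryl group on that carbon by the phenylethenyl group and raised the number by a modest amount; the present change restores an aryl group there, so a downward step of comparable size is expected in this assay, with added uncertainty because neither aryl group measured carried methoxy groups. The expected step is a 5.0-fold lower number from compound 3 to compound 4 (0.70 log units; beyond the scatter). Compound 4 is therefore estimated at 8000 nM, within 3000 nM to 25000 nM.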

Compound 4, concentration lethal to 50% of the cells: 37400 nM
The estimate for compound 4 lay 4.7-fold (0.67 log units) below the measured number, outside the stated range (above it).
By their numbers in this assay, from the lowest: compounds 2 and 1 (each within the scatter of the next); then compounds 4 and 3 (each within the scatter of the next).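

In this assay, restoring an aryl group on the saturated ring carbon does not by itself give the lower number (a 1.1-fold lower number from compound 3 to compound 4 (0.03 log units; within the scatter)). The aryl groups instead separate from one another, with 3,4-dimethoxyphenyl giving a higher number than either 2-chlorophenyl (a 6.4-fold higher number from compound 2 to compound 4 (0.81 log units; beyond the scatter)) or 2-hydroxyphenyl (a 6.4-fold higher number from compound 1 to compound 4 (0.80 log units; beyond the scatter)). At this position, the 3,4-dimethoxyphenyl and 2-phenylethenyl groups therefore stand within the scatter of each other, apart from the other two aryl groups.

No available evidence accounts for this separation. Still open, as far as these compounds go, is how a phenyl group carrying a single methoxy group, or an amine, would behave on this carbon.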